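Phenyl for butyl on the hydroxyacyl chain

The compounds below may be only part of what the source reports. "The series", "measured", "known", "first", "only" and "open" are said of these compounds alone.

Compound 1 `CCCC[C@@H](O)C(=O)N1N=CC[C@H]1C(=O)NCc1cc(Cl)ccc1-n1cnnn1` was examined in an ADME assay on liver for metabolic stability, with Liver microsome (Rattus norvegicus) as the target, read by LC-MS, using microsomes; on this read-out higher numbers stand for fast clearance and lower numbers for slow clearance. In this assay compound 1 gives < 15 mL.min-1.g-1, which is a limit of the assay and not a measured number. Two other compounds were run alongside it. Compound 2 `CC(C)(C)[C@@H](O)C(=O)N1C[C@@H]2C[C@@H]2[C@H]1C(=O)NCc1cc(Cl)ccc1-n1cnnn1` gives in this assay < 15 mL.min-1.g-1, again a limit. Compound 3 `O=C(NCc1cc(Cl)ccc1-n1cnnn1)[C@@H]1C[C@@H]2C[C@@H]2N1C(=O)[C@H](O)c1ccccc1` gives in this assay < 15 mL.min-1.g-1, also a limit. Compound 1 therefore stands at the same limit as the other two, and no order among the three can be drawn because of the limit of < 15 mL.min-1.g-1 in this assay, at which 3 of the 3 values shown sit.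

Compound 4 `O=C(NCc1cc(Cl)ccc1-n1cnnn1)[C@@H]1CC=NN1C(=O)[C@H](O)c1ccccc1` has not yet been measured. It differs from compound 1 in one place: phenyl in place of butyl on a saturated chain carbon bound to a carbonyl carbon and an oxygen on a saturated carbon. Among the measured compounds shown here, no step between two measured compounds is available to anchor this change. Compound 3 already carries phenyl in the corresponding position on its own core and sits at the limit. On that basis the step from compound 1 to compound 4 is expected to be a step that the limit leaves unreadable from compound 1 to compound 4, no change beyond the scatter. Compound 4 is accordingly estimated at 10 mL.min-1.g-1 in this assay, within a range of 3 mL.min-1.g-1 to 25 mL.min-1.g-1.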

Compound 4, intrinsic clearance in microsomes: < 15 mL.min-1.g-1
Compound 4 was reported as a limit; the forecaster's own chance of this, stated with the estimate: 70%; the middle value does not contradict the limit.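

In this assay, among the compounds shown here, compound 1 and compound 4 both sit at a limit, so no step from butyl to phenyl can be read between them: the limit of < 15 mL.min-1.g-1 in this assay, at which 4 of the 4 values shown sit.

The compounds shown leave open how fast each is actually cleared and whether phenyl and butyl differ at all on this read-out.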